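The source may report more compounds than this note shows. Statements on the series, on what has been measured and on what is new or still open speak of the compounds shown alone.

Measured compounds:
- compound 1 `COc1cc(-c2cc(/C=C/C(=O)c3ccc(Cl)c(Cl)c3)[nH]n2)cc(OC)c1OC`: 96%
- compound 2 `COc1ccc(-c2cc(/C=C/C(=O)c3ccc(N)cc3)[nH]n2)cc1OC`: 90%
- compound 3 `COc1ccc(-c2cc(/C=C/C(=O)c3ccc(N)cc3)[nH]n2)cc1`: 96%

In a functional assay on UACC-257 cells (Homo sapiens) for cytotoxicity, read by sulforhodamine B assay, with a stated time of 48 h, tested at 0.01 uM (on this read-out lower numbers stand for a stronger effect and higher numbers for a weaker effect at the one concentration tested), compound 1 gives 96%. On this read-out compound 1 stands level with compound 3, and its gap to compound 2 lies within the scatter, so the three numbers cannot be told apart. Among the measured compounds shown here, the only step between two measured compounds, a number 6 percentage points higher from compound 2 to compound 3 (within the scatter), swaps a methoxy for hydrogen on an aromatic carbon and leaves the read-out unchanged beyond the scatter.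

Compound 4 `COc1ccc(C(=O)/C=C/c2cc(-c3cc(OC)c(OC)c(OC)c3)n[nH]2)cc1OC` has not yet been measured. It differs from compound 1 in one place: 3,4-dimethoxyphenyl in place of 3,4-dichlorophenyl on a carbonyl carbon. For the measured compounds named here, no measured step concerns this part of the molecule, so the single step that exists, a number 6 percentage points higher from compound 2 to compound 3 (within the scatter), bears on it only by showing that a change on an aromatic ring of this core did not move the number. The expectation is therefore no step beyond the scatter, a number 2 percentage points lower from compound 1 to compound 4 (within the scatter). Compound 4 is estimated at 94% in this assay, expected to fall between 82% and 100%.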

Compound 4, a percentage reported as activity, at one concentration (the size of the read-out at that concentration, not a potency): 85%
For compound 4 the middle estimate is 9 percentage points above the measured one, and the stated range covers the measured number.
By their numbers in this assay, from the lowest: compounds 4, 2, 1 and 3 (each within the scatter of the next, the first and the last beyond it).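

The ring on the carbonyl carbon is not a silent part of the molecule: in this assay, placing 3,4-dimethoxyphenyl where 3,4-dichlorophenyl stood gives a number 11 percentage points lower from compound 1 to compound 4 (beyond the scatter), a modest move toward a stronger effect at the one concentration tested. The only earlier step, a number 6 percentage points higher from compound 2 to compound 3 (within the scatter), changed a different part of the molecule, so this is the first change shown that clears the scatter. Nothing available explains this shift.

Among the compounds shown here, it remains open whether the shift comes from gaining the methoxy groups or from losing the chlorines, and a ring carrying only one of either group could help separate the two. As far as these compounds go, how this position would respond to quite different groups, such as a carboxylic acid or a morpholine on the ring, also remains unknown.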